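The source may hold more compounds than are shown below. What is called first, only, known or untested is meant among the compounds shown, and "the series" means these compounds.

Measured so far in an assay on microsomes from liver for inhibition of acyl-CoA desaturase 1 (Rattus norvegicus); a higher number here means a weaker inhibitor, a lower number a stronger inhibitor:

Compound 1 `OCc1nnc(-c2ccc(N3CCC(Oc4ccccc4C(F)(F)F)CC3)nn2)s1`: 3.2 nM
Compound 2 `CC(C)Cc1nnc(-c2ccc(N3CCC(Oc4ccccc4C(F)(F)F)CC3)nn2)s1`: 37 nM
Compound 3 `OCc1nnc(-c2ccc(N3CCC(Oc4ccccc4C(F)(F)F)CC3)nn2)o1`: 2.9 nM

Compounds 1 and 3 share the hydroxymethyl-bearing five-membered ring substituent on the same core and differ only in that ring: 5-(hydroxymethyl)-1,3,4-oxadiazol-2-yl in place of 5-(hydroxymethyl)-1,3,4-thiadiazol-2-yl on an aromatic carbon. Their values sit together, the step of a 1.1-fold lower number from compound 1 to compound 3 (0.04 log units; within the scatter) staying within the scatter, so nothing can be read into the choice between the two rings on this evidence.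

Compound 2 carries the change (isopropyl in place of hydroxy on a saturated chain carbon bound to an aromatic carbon). Its step from compound 1, a 12-fold higher number from compound 1 to compound 2 (1.06 log units; beyond the scatter), is large and beyond the scatter. The comparison of compound 2 with compound 3, a 13-fold lower number from compound 2 to compound 3 (1.11 log units; beyond the scatter), combines that change with the ring exchange and lands at a similar size, consistent with the ring exchange itself contributing little.

Compound 4 `CC(C)Cc1nnc(-c2ccc(N3CCC(Oc4ccccc4C(F)(F)F)CC3)nn2)o1` has not been measured in this assay. For the measured compounds named here, it is related to compound 3 by isopropyl in place of hydroxy on a saturated chain carbon bound to an aromatic carbon, which is the same change as the one from compound 1 to compound 2, made at the same place and on the oxadiazole-bearing core instead of the thiadiazole-bearing one. Going by the values given here, since the two cores give values within the scatter of each other, and since the only measured instance of this change is a 12-fold higher number from compound 1 to compound 2 (1.06 log units; beyond the scatter), a step of about a 12-fold higher number from compound 3 to compound 4 (1.08 log units; beyond the scatter) is expected for compound 4. Among the compounds with values here, the estimate for compound 4 in this assay is 35 nM, with a likely span from 15 nM to 90 nM; the single measured precedent for the change is the main source of uncertainty.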

Compound 4, half-maximal inhibitory concentration: 15 nM
Compound 4: middle estimate off by 2.3-fold (0.37 log units), on the high side; measured number inside the range.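

In this assay, isobutyl in place of hydroxymethyl gives a higher number on both cores, and the size of the step carries over from one core to the other as far as these pairs can tell: the same change on two cores in this assay, a 12-fold higher number (1.06 log units; beyond the scatter) from compound 1 to compound 2 and a 5.2-fold higher number (0.71 log units; beyond the scatter) from compound 3 to compound 4, 2.2-fold (0.35 log units) apart, within the scatter of two such steps. On the oxadiazole-bearing core the step is a 5.2-fold higher number from compound 3 to compound 4 (0.71 log units; beyond the scatter), while the exchange of rings, which left the hydroxymethyl pair within the scatter, is beyond it in the isobutyl pair, at a 2.5-fold lower number from compound 2 to compound 4 (0.39 log units; beyond the scatter), and a 4.7-fold higher number from compound 1 to compound 4 (0.67 log units; beyond the scatter) combines the side-chain change with the ring exchange. For the compounds shown here, with only two pairs, and a gap between their steps that stays within the scatter, the data show neither that the change acts differently on the two cores nor that its size would hold on any further core.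

The compounds shown place only hydroxymethyl and isobutyl at this position, so it remains open whether the step follows from losing the hydroxy or from gaining the isopropyl. An ethyl or a longer chain, an aminomethyl group or a carboxylic acid at the same place, each compared on both cores, would bear on that question and on how far the transfer holds.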